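Propyl to methylsulfanyl on the aminopyrimidine series

The source may hold more compounds than are shown below. What is called first, only, known or untested is meant among the compounds shown, and "the series" means these compounds.

Three compounds have a number in a functional assay (aorta) with Oryctolagus cuniculus as the target; a lower number here means a stronger inhibitor, a higher number a weaker inhibitor. Compound 1 `OCc1ccc(-c2nn(Cc3c(F)cccc3F)c3ccccc23)o1` gives 15000 nM, compound 2 `OCc1ccnc(-c2nn(Cc3ccccc3F)c3ncccc23)n1` gives 1300 nM, and compound 3 `CCCc1cnc(-c2nn(Cc3ccccc3F)c3ncccc23)nc1N` gives 252000 nM. Compound 3 therefore stands at the highest of the three numbers: it lies beyond the scatter above compound 1, its nearest neighbour, and still further above compound 2, the lowest of the set. Going by the values given here, no two of the measured compounds differ in one place only, so no step between measured compounds is available to calibrate what a single exchange does here.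

Compound 4 `CSc1cnc(-c2nn(Cc3ccccc3F)c3ncccc23)nc1N` is the next compound to be measured. It differs from compound 3 as follows: methylsulfanyl in place of propyl on an aromatic carbon. The rest of the structure is unchanged.

Among the compounds with values here, with no comparable step among the measured compounds, the expectation for compound 4 rests on compound 3 alone, whose number 252000 nM sets the starting point. The exchange is small in what leaves and what enters, so for compound 4 a step of a 1.3-fold lower number from compound 3 to compound 4 (0.10 log units; within the scatter) is expected, that is, none beyond the scatter, with no firm direction. Compound 4 is estimated at 200000 nM, with a range of 60000 nM to 700000 nM.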

Compound 4, half-maximal inhibitory concentration: 243000 nM
The estimate for compound 4 lay 1.2-fold (0.08 log units) below the measured number, within the range that was stated.
By their numbers in this assay, from the lowest: compound 2; then compound 1; then compounds 4 and 3 (each within the scatter of the next).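

In this assay, going by these compounds alone, the exchange of propyl for methylsulfanyl gives the first step that changes a single place: a 1.0-fold lower number from compound 3 to compound 4 (0.02 log units; within the scatter). At this aromatic carbon, ortho to an amino group and para to a large group, the read-out therefore does not separate the two groups, although sulfur and a hydrogen-bond acceptor enter where propyl carried neither. Nothing measured here accounts for this result.

Within the data shown here, this single step covers only one pair of groups at one position, with compound 3 and compound 4 both far from the lowest number in the set, so it does not show whether this position is insensitive to change in general; a carboxylic acid, a dimethylamino group or a longer chain such as hexyl could give a different answer. Also open, from the compounds shown here alone, is whether methylsulfanyl in place of propyl would give a similar step on a compound that differs elsewhere in the structure, where the starting number is lower.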